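A few compounds are considered here, and "the series" means these few. Any claim that something is new, unique, unknown or untested is made for them only; others in the source may bear on it.

Compound 1 `Cc1cccc2sc(NC(=O)CCN3CCN(C(C)(C)C)CC3)nc12`, compound 2 `CCCCN1CCN(CCC(=O)Nc2nc3c(C)cccc3s2)CC1` and compound 3 `CCCCCCN1CCN(CCC(=O)Nc2nc3c(C)cccc3s2)CC1` share one core and differ only in the group on an amine nitrogen in a ring. In an assay on membranes from liver for displacement of a labelled ligand from Sigma intracellular receptor 2 (Rattus norvegicus), read by scintillation counting, with a stated time of 120 min (a lower number here means a stronger inhibitor, a higher number a weaker inhibitor), compound 1 gives 200 nM, compound 2 gives 1200 nM and compound 3 gives 158 nM, the lowest of the three, though its gap to compound 1 stays within the scatter. The steps are a 6.0-fold higher number from compound 1 to compound 2 (0.78 log units; beyond the scatter), a 7.6-fold lower number from compound 2 to compound 3 (0.88 log units; beyond the scatter) and a 1.3-fold lower number from compound 1 to compound 3 (0.10 log units; within the scatter). Compound 4 `Cc1cccc2sc(NC(=O)CCN3CCN(CC4CCCO4)CC3)nc12` carries oxolan-2-yl in place of pentyl on a saturated chain carbon bound to an amine nitrogen in a ring; taken one bond further out, hexyl becomes (oxolan-2-yl)methyl. Among the compounds with values here, no measured step trades carbon for oxygen in this chain, so the bearing steps are only indirect, and a modest rise in this assay is expected, a 2.0-fold higher number from compound 3 to compound 4 (0.31 log units; beyond the scatter). For compound 4 the estimate is 320 nM, within 100 nM to 1000 nM.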

Compound 4, inhibition constant: 5000 nM
Compound 4: the middle estimate sits 16-fold (1.19 log units) below what was measured; measured number outside the range, above it.
By their numbers in this assay, from the lowest: compounds 3 and 1 (each within the scatter of the next); then compound 2; then compound 4.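

Within the data shown here, on the amine nitrogen in a ring, alkyl groups were the only groups seen before, and (oxolan-2-yl)methyl brings a larger change in this assay than any step among them (a 32-fold higher number from compound 3 to compound 4 (1.50 log units; beyond the scatter); a 25-fold higher number from compound 1 to compound 4 (1.40 log units; beyond the scatter)). Compound 4 also lies beyond the butyl compound (a 4.2-fold higher number from compound 2 to compound 4 (0.62 log units; beyond the scatter)), so this group gives the weakest binder of the four, and a hexyl-sized group alone does not secure a low number here. No measured evidence accounts for this rise.

The compounds shown leave open whether the ring oxygen or the ring itself goes with the step. A cyclopentylmethyl group or an open-chain ether on the same nitrogen would separate the two.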